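Replacing (azetidin-1-yl)methyl with pyridin-3-yl on a shared core

The source may report more compounds than this note shows. Statements on the series, on what has been measured and on what is new or still open speak of the compounds shown alone.

Compound 1 `O=C1NC(=O)c2c1c1c3ccc(CN4CCCNCC4)cc3[nH]c1c1c2c2cccc3c2n1CCC3`: 7600 nM
Compound 2 `O=C1NC(=O)c2c1c1c3ccc(C(F)(F)F)cc3[nH]c1c1c2c2cccc3c2n1CCC3`: 1480 nM
Compound 3 `O=C1NC(=O)c2c1c1c3ccc(CN4CCC4)cc3[nH]c1c1c2c2cccc3c2n1CCC3`: 230 nM

All three values come from a functional assay on HCT-116 cells (Homo sapiens) for cytotoxicity; a lower number here means a stronger inhibitor, a higher number a weaker inhibitor. Compound 3 has the lowest number of the three, which makes it the strongest inhibitor measured so far. The next structure, compound 4 `O=C1NC(=O)c2c1c1c3ccc(-c4cccnc4)cc3[nH]c1c1c2c2cccc3c2n1CCC3`, keeps the shared core and changes one group: pyridin-3-yl in place of (azetidin-1-yl)methyl on an aromatic carbon. Among the measured compounds shown here, no measured compound carries pyridin-3-yl, so no step shows this change directly, and only neighbouring steps can guide an expectation. Putting (azetidin-1-yl)methyl in place of trifluoromethyl gave a 6.4-fold lower number from compound 2 to compound 3 (0.81 log units; beyond the scatter). Putting azetidin-1-yl in place of 1,4-diazepan-1-yl gave a 33-fold lower number from compound 1 to compound 3 (1.52 log units; beyond the scatter). For the measured compounds named here, both steps end at compound 3, and the group that compound 4 gives up is the one present in the strongest compound so far. A modest move towards a weaker number therefore seems most likely, although the large step shows that changes here can go far. The expected step is a 2.8-fold higher number from compound 3 to compound 4 (0.45 log units; beyond the scatter). Compound 4 is estimated at 650 nM, with an expected range from 180 nM to 2400 nM.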

Compound 4, half-maximal inhibitory concentration: 1130 nM
The estimate for compound 4 lay 1.7-fold (0.24 log units) below the measured number; measured number inside the range.
By their numbers in this assay, from the lowest: compound 3; then compounds 4 and 2 (each within the scatter of the next); then compound 1.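

In this assay, pyridin-3-yl gives a 4.9-fold higher number from compound 3 to compound 4 (0.69 log units; beyond the scatter) when it replaces (azetidin-1-yl)methyl on this aromatic carbon, even though both groups hold one ring and one nitrogen. The counts of hydrogen-bond donors and acceptors are also the same for the two groups, so these counts alone do not account for the gap. Pyridin-3-yl and trifluoromethyl cannot be told apart here, with a 1.3-fold lower number from compound 2 to compound 4 (0.12 log units; within the scatter) as their step, whereas a 6.7-fold lower number from compound 1 to compound 4 (0.83 log units; beyond the scatter) shows that pyridin-3-yl in place of (1,4-diazepan-1-yl)methyl lowers the number clearly.

Still open, on these data alone, is how a plain phenyl ring, a pyridin-4-yl ring or a (pyrrolidin-1-yl)methyl group would compare at this position. Nothing measured here explains why these groups differ.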